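The compounds below may be only part of what the source reports. "The series", "measured", "known", "first", "only" and "open" are said of these compounds alone.

In a functional assay on KYSE-70 cells for antiproliferative activity against KYSE-70 cell line (Homo sapiens), read by MTT assay, with a stated time of 72 h (on this read-out higher numbers stand for weaker inhibition and lower numbers for stronger inhibition), compound 1 `CC(=O)c1ccc(-c2ccc3c(C(=O)Nc4cccc(F)c4)cc(=O)[nH]c3c2)cc1`, which carries 4-acetylphenyl on the shared core, gives > 20000 nM, a limit of the assay and not a number. Compound 2 `Nc1ccc(-c2ccc3c(C(=O)Nc4cccc(F)c4)cc(=O)[nH]c3c2)cc1`, with 4-aminophenyl there instead, gives > 20000 nM, again a limit. As far as these compounds go, compound 3 `O=C(Nc1cccc(F)c1)c1cc(=O)[nH]c2cc(-c3ccc(F)nc3)ccc12`, with 6-fluoropyridin-3-yl, gives > 20000 nM, which is also a limit, so its true standing is unknown.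

Compound 4 `O=C(Nc1cccc(F)c1)c1cc(=O)[nH]c2cc(-c3cccnc3F)ccc12` has the same atoms as compound 3, joined differently, with 2-fluoropyridin-3-yl in place of 6-fluoropyridin-3-yl on an aromatic carbon.

The measured changes at this same place on the core offer little guidance. They are a step that the two limits leave unreadable from compound 1 to compound 3, a step that the two limits leave unreadable from compound 2 to compound 3 and a step that the two limits leave unreadable from compound 1 to compound 2, and none has a size that can be read. What they do show is the limit of > 20000 nM in this assay, at which 3 of the 3 values shown sit. With no readable step to draw on, no change beyond the usual scatter is expected, and the expected move is a number no higher from compound 3 to compound 4 (the limit leaves the size open). Compound 4 is estimated at 20000 nM, with an expected range from 9000 nM to 40000 nM, and it may well be reported only as a limit.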

Compound 4, half-maximal inhibitory concentration: > 20000 nM
Compound 4 was reported as a limit; the forecaster's own chance of this, stated with the estimate: 80%; the middle value lies on the limit itself.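

Within the data shown here, compound 4 gives > 20000 nM as a limit and not a number, so no step between it and compound 1, compound 2 or compound 3 can be read: the limit of > 20000 nM in this assay, at which 4 of the 4 values shown sit. As far as these compounds go, whether any group at this place on the shared core gives a measurable value in this assay stays open.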